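The compounds below may be only part of what the source reports. "The series", "measured", "known", "first", "only" and "open" are said of these compounds alone.

Measured in a functional assay on A2780 cells (Homo sapiens) for antiproliferative activity, read by resazurin assay, with a stated time of 72 h; a higher number here means a weaker inhibitor, a lower number a stronger inhibitor:
- compound 1 `CCCN(C)C(=O)c1cc2c(Cc3ccccc3)n[nH]c2cc1O`: > 10000 nM (a limit of the assay, not a number)
- compound 2 `CN(Cc1cccc(Br)c1)C(=O)c1cc2c(Cc3ccccc3)n[nH]c2cc1O`: 7100 nM

Within the data shown here, compound 2, at 7100 nM, holds the only actual number so far. Among the measured compounds shown here, the one measured step, an at least 1.4-fold lower number from compound 1 to compound 2 (0.14 log units; that floor lies within the scatter), lies within the scatter at its floor. As far as these compounds go, it starts from the limit of > 10000 nM in this assay, at which 1 of the 2 values shown sits, so its true size remains open.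

Compound 3 `COc1cccc(CN(C)C(=O)c2cc3c(Cc4ccccc4)n[nH]c3cc2O)c1OC` carries 2,3-dimethoxyphenyl in place of 3-bromophenyl on a saturated chain carbon bound to an amide-type nitrogen. For the measured compounds named here, no measured step compares two substituted phenyl groups at this place, so the step from compound 1 gives no direction. No change beyond the scatter is therefore expected in this assay, and a reading at the assay limit is possible. The expected step is a 1.1-fold higher number from compound 2 to compound 3 (0.05 log units; within the scatter). Compound 3 is estimated at 8000 nM, with an expected range of 3500 nM to 18000 nM.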

Compound 3, half-maximal inhibitory concentration: 4800 nM
Beside the measured number, compound 3's estimate is 1.7-fold (0.22 log units) above it, within the range that was stated.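

In this assay, two substituted phenyl groups can now be compared on a saturated chain carbon bound to an amide-type nitrogen, and the step, a 1.5-fold lower number from compound 2 to compound 3 (0.17 log units; within the scatter), does not separate 2,3-dimethoxyphenyl from 3-bromophenyl, although the first holds 2 hydrogen-bond acceptors and the second holds 0. Replacing ethyl with a substituted phenyl group now gives a step that clears the scatter, an at least 2.0-fold lower number from compound 1 to compound 3 (0.31 log units; beyond the scatter), which the floor of the earlier step from the same starting point did not do. That figure is only a floor, and the true size of the step stays open: the limit of > 10000 nM in this assay, at which 1 of the 3 values shown sits.

As far as these compounds go, whether an amine, a carboxylic acid or a longer chain at this place would move the number beyond the scatter remains open. The compounds shown also do not separate the contributions of the two methoxy groups of 2,3-dimethoxyphenyl.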